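This account rests on a few compounds, and the source may have more. Where it says the series, first, only, none or still open, it means among the compounds named here.

Measured compounds in a functional assay on MCF7 cells (Homo sapiens) for inhibition; on this read-out lower numbers stand for stronger inhibition and higher numbers for weaker inhibition:

compound 1, `COc1c(C)cnc(CN2c3nc(N)nc(Cl)c3NC(=O)[C@H]2C)c1C` — 790 nM
compound 2, `COc1c(C)cnc(CN2CC(=O)N(C(C)C)c3c(Cl)nc(N)nc32)c1C` — 50 nM
compound 3, `COc1c(C)cnc(CN2CC(=O)N(CCCC(C)C)c3c(Cl)nc(N)nc32)c1C` — 3110 nM

Compound 3 gives the highest number of the three in this assay: the nearest is compound 1, the furthest compound 2, and both gaps lie beyond the scatter. Compound 4, `COc1c(C)cnc(CN2CC(=O)N(C)c3c(Cl)nc(N)nc32)c1C`, has not been measured. It differs from compound 3 by hydrogen in place of isopentyl on a saturated chain carbon bound to an amide-type nitrogen in a ring; the same change, cut one bond further out, reads 4-methylpentyl to methyl.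

Among the measured compounds shown here, one measured step bears on the amide-type nitrogen in the ring: a 62-fold higher number from compound 2 to compound 3 (1.79 log units; beyond the scatter). The step from compound 3 to compound 4 runs the other way on the same position and goes further, to the smallest chain in the set, so a fall in the number is expected, plausibly of a size near the earlier step. For the measured compounds named here, compound 1 carries the hydrogen on that nitrogen with the methyl placed elsewhere, and no step to it is counted here, so it only anchors the range.

For compound 4 the expected step is a 31-fold lower number from compound 3 to compound 4 (1.49 log units; beyond the scatter), giving an estimated 100 nM, within 20 nM to 600 nM.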

Compound 4, half-maximal inhibitory concentration: 2190 nM
The estimate for compound 4 lay 22-fold (1.34 log units) below the measured number; measured number outside the range, above it.
By their numbers in this assay, from the lowest: compound 2; then compound 1; then compounds 4 and 3 (each within the scatter of the next).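

In this assay, methyl in place of 4-methylpentyl on the amide-type nitrogen in the ring gives a 1.4-fold lower number from compound 3 to compound 4 (0.15 log units; within the scatter) and so leaves the number unresolved across this large change in chain size. Methyl in place of isopropyl gives a 44-fold higher number from compound 2 to compound 4 (1.64 log units; beyond the scatter) as a large rise, so among the three groups on this nitrogen, both methyl and 4-methylpentyl go against isopropyl, and the number does not track chain size across these compounds. No measured evidence accounts for this behaviour.

The compounds shown leave open whether the low number of compound 2 is specific to isopropyl or is shared by groups such as ethyl, cyclopropyl or tert-butyl on this nitrogen. From the compounds shown here alone, how a chain ending in an amine or a carboxylic acid would read at this position also remains open.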